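Phenyl to butyl on the chain of compound 3

This account rests on a few compounds, and the source may have more. Where it says the series, first, only, none or still open, it means among the compounds named here.

Measured compounds:
Compound 1 `O=Cc1coc(C(=O)CCCCCCc2ccccc2)n1` gives 1510 nM in an assay on HEK-293T cells for inhibition of diacylglycerol lipase-alpha (Homo sapiens), read by colorimetric assay; a higher number here means a weaker inhibitor, a lower number a stronger inhibitor.
Compound 2 `O=C(CCCCCCc1ccccc1)c1ncc(-c2ccc(C(=O)C(F)(F)F)cc2)o1` reaches only the limit > 10000 nM in this assay; this is a limit of the assay, not a number.
Compound 3 `O=C(CCCc1ccccc1)c1nc2ncccc2o1` gives 2240 nM in this assay.

Among the two numbers, compound 3 has the higher one, but its nearest neighbour, compound 1, lies within the scatter of it. Compound 4 `CCCCCCCC(=O)c1nc2ncccc2o1` differs from compound 3 in one place: butyl in place of phenyl on a saturated chain carbon, three bonds along the chain from a carbonyl carbon. For the measured compounds named here, no measured step shows this change. For compound 4 a small loss, at the edge of the scatter, is expected, a 1.6-fold higher number from compound 3 to compound 4 (0.19 log units; within the scatter). Compound 4 is therefore estimated at 3500 nM, between 1200 nM and 10000 nM.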

Compound 4, half-maximal inhibitory concentration: 631 nM
Compound 4: the middle estimate sits 5.5-fold (0.74 log units) above what was measured; measured number outside the range, below it.
By their numbers in this assay, from the lowest: compound 4; then compounds 1 and 3 (each within the scatter of the next). At a limit, above all of these: compound 2.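

In this assay, the change gives a 3.5-fold lower number from compound 3 to compound 4 (0.55 log units; beyond the scatter) and so shows that a phenyl is not needed at this place on the chain for inhibition, which compounds 1, 2 and 3, all carrying a phenyl, could not show. Butyl, with no ring, does better here than phenyl on the same core. Nothing measured here accounts for this step. Still open, on these data alone, is whether a longer chain, an amine or a carboxylic acid in place of butyl would hold this gain, and whether the same change would act alike on the core of compound 1.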